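The source may hold more compounds than are shown below. What is called first, only, known or untested is meant among the compounds shown, and "the series" means these compounds.

Working notes on the series. In a functional assay on MCF7 cells (Homo sapiens) for antiproliferative activity, read by MTT assay, with a stated time of 72 h (a higher number here means a weaker inhibitor, a lower number a stronger inhibitor), compound 1 (`O=C(NCc1ccccc1)c1csc(NC(=S)Nc2ccc(Cl)cc2)n1`) stands at 56500 nM and compound 2 (`CCOC(=O)c1csc2nc(CN3CCN(Cc4ccccc4)CC3)c(-c3ccc(C)cc3)n12`) at 29100 nM with the two values within the scatter of each other. No order can be drawn between them. Among the measured compounds shown here, the two structures are not connected by a change in one place, so the series so far offers no measured step to serve as a guide.

The next compound to be read is compound 3 (`CCOC(=O)c1csc2nc(CN3CCN(Cc4ccccc4)CC3)c(-c3ccc(OC)cc3)n12`), which differs from compound 2 in one place: methoxy in place of methyl on an aromatic carbon, para to a large group, so that 4-methylphenyl becomes 4-methoxyphenyl (methoxy in place of methyl on an aromatic carbon) while the rest of the structure stays the same.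

For the measured compounds named here, with no precedent for this change, no shift beyond the scatter is expected in this assay and neither direction is favoured. The expectation is anchored on compound 2 at 29100 nM as the closest structure available. The estimated step is a 1.1-fold lower number from compound 2 to compound 3 (0.03 log units; within the scatter) and it is expected to stay small. The estimate for compound 3 is 27000 nM with an expected range of 11000 nM to 65000 nM for the measurement.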

Compound 3, half-maximal inhibitory concentration: 17100 nM
Beside the measured number, compound 3's estimate is 1.6-fold (0.20 log units) above it; the measured number falls inside the stated range.
By their numbers in this assay, from the lowest: compounds 3, 2 and 1 (each within the scatter of the next, the first and the last beyond it).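

In this assay, the series now has its first measured step, a 1.7-fold lower number from compound 2 to compound 3 (0.23 log units; within the scatter), so methoxy in place of methyl on an aromatic carbon, para to a large group, gives no order between the two compounds. At this position, therefore, 4-methylphenyl and 4-methoxyphenyl cannot be told apart by this read-out, even though methoxy brings an oxygen and a hydrogen-bond acceptor that methyl does not have. No available measurement bears on the basis of this step.

Among the compounds shown here, with only one change read at this position, it remains open whether a group such as chloro, hydroxyl or an amine on the same aromatic carbon would give a step beyond the scatter. Going by these compounds, it also remains open whether a longer chain on the oxygen, such as ethoxy in place of methoxy, would leave the number within the scatter of the two compounds that now define this position.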